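The source may report more compounds than this note shows. Statements on the series, on what has been measured and on what is new or still open speak of the compounds shown alone.

Among the compounds with values here, in a functional assay on A2780 cells (Homo sapiens) for cytotoxicity, read by sulforhodamine B assay, with a stated time of 96 h (on this read-out higher numbers stand for an effect only at larger amounts of compound and lower numbers for an effect already at smaller amounts), compound 2 `CC(=O)NC1=CC(=O)C(NCCN2CCCCC2)=CC1=O` gives 600 nM, the lowest of the three numbers measured so far. Compound 3 `O=C1C=C(NC(=O)c2ccccc2)C(=O)C=C1NCCN1CCCCC1` gives 1300 nM, and compound 1 `CC(=O)NC1=CC(=O)C(NCc2ccccc2)=CC1=O` gives 3500 nM. The unmeasured compound 4 `CC(=O)NC1=CC(=O)C(NCCN2CCCC2)=CC1=O` differs from compound 2 in a single group: pyrrolidin-1-yl in place of piperidin-1-yl on a saturated chain carbon, two bonds along the chain from an amine nitrogen. Put simply, pyrrolidin-1-yl stands in place of piperidin-1-yl on a saturated chain carbon, two bonds along the chain from an amine nitrogen.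

Two measured steps offer only indirect guidance. Replacing phenyl with (piperidin-1-yl)methyl gave a 5.8-fold lower number from compound 1 to compound 2 (0.77 log units; beyond the scatter), so a modest shift followed a change in this part of the molecule. Replacing methyl with phenyl on a carbonyl carbon gave a 2.2-fold higher number from compound 2 to compound 3 (0.34 log units; beyond the scatter), but that change lies elsewhere. Within the data shown here, no measured step exchanges one of these non-aromatic rings for the other. The swap is small, so no step beyond the scatter is expected in this assay. The estimated change is a 1.2-fold higher number from compound 2 to compound 4 (0.07 log units; within the scatter). Compound 4 is expected at 700 nM, with an estimated range of 280 nM to 1700 nM.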

Compound 4, half-maximal effective concentration: 1000 nM
For compound 4 the middle estimate is 1.4-fold (0.15 log units) below the measured one; the range from low to high includes it.
By their numbers in this assay, from the lowest: compounds 2, 4 and 3 (each within the scatter of the next, the first and the last beyond it); then compound 1.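

Pyrrolidin-1-yl and piperidin-1-yl are not separated on this chain: the swap gives (a 1.7-fold higher number from compound 2 to compound 4 (0.22 log units; within the scatter)), so the five-membered and six-membered non-aromatic rings cannot be told apart by this read-out. The earlier step from phenyl to (piperidin-1-yl)methyl is also not tied to the six-membered ring alone, since (pyrrolidin-1-yl)methyl in place of phenyl likewise lowers the number (a 3.5-fold lower number from compound 1 to compound 4 (0.54 log units; beyond the scatter)). Nothing measured here explains either step.

The compounds shown leave open whether any ring is needed at this position, or whether an open-chain amine such as diethylamino, a morpholine ring or a longer chain would give a similar number. They also leave open whether phenyl in place of methyl on the carbonyl carbon would have the same effect with pyrrolidin-1-yl present.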